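A carboxymethyl side chain on the amide in compound 4

This account rests on a few compounds, and the source may have more. Where it says the series, first, only, none or still open, it means among the compounds named here.

- compound 1 `CCn1c(C(=O)NC2(CO)CC2)ccc1C(CC)(CC)c1ccc(OCS(=O)(=O)c2ccccc2)c(C)c1`: 3560 nM
- compound 2 `CCn1c(C(=O)NCCCO)ccc1C(CC)(CC)c1ccc(OCS(=O)(=O)c2ccccc2)c(C)c1`: 11300 nM
- compound 3 `CCn1c(C(=O)N[C@H](CO)CCO)ccc1C(CC)(CC)c1ccc(OCS(=O)(=O)c2ccccc2)c(C)c1`: 12100 nM

In a functional assay on PC-3 cells (Homo sapiens) for antiproliferative activity, read by MTT assay, with a stated time of 24 h (a lower number here means a stronger inhibitor, a higher number a weaker inhibitor), compound 3 gives 12100 nM. The scatter does not separate it from its nearest neighbour, as shown by a 1.1-fold higher number from compound 2 to compound 3 (0.03 log units; within the scatter). Only compound 1 stands clearly apart, with a 3.4-fold higher number from compound 1 to compound 3 (0.53 log units; beyond the scatter).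

Compound 4 `CCn1c(C(=O)NCC(=O)O)ccc1C(CC)(CC)c1ccc(OCS(=O)(=O)c2ccccc2)c(C)c1` carries carboxymethyl in place of 3-hydroxy-1-(hydroxymethyl)propyl on an amide-type nitrogen. Earlier changes at this nitrogen were modest or smaller, such as a 3.2-fold higher number from compound 1 to compound 2 (0.50 log units; beyond the scatter). Going by the values given here, none of the measured compounds carries carboxymethyl, so the range stays wide. No shift beyond the scatter is expected in either direction, and the expected change is a 1.0-fold lower number from compound 3 to compound 4 (0.00 log units; within the scatter). For compound 4 the estimate is 12000 nM, with an expected range from 4000 nM to 36000 nM.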

Compound 4, half-maximal inhibitory concentration: 30100 nM
Compound 4: the middle estimate sits 2.5-fold (0.40 log units) below what was measured, within the range that was stated.
By their numbers in this assay, from the lowest: compound 1; then compounds 2 and 3 (each within the scatter of the next); then compound 4.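

In this assay, carboxymethyl on the amide-type nitrogen gives the highest number of the set, so it is the weakest compound here, and it separates from both open-chain alcohols (a 2.5-fold higher number from compound 3 to compound 4 (0.40 log units; beyond the scatter); a 2.7-fold higher number from compound 2 to compound 4 (0.43 log units; beyond the scatter)). Going by these compounds alone, those two alcohols could not be told apart, so this is the first change from either of them that moves the number beyond the scatter. It also opens the widest gap seen at this nitrogen (an 8.5-fold higher number from compound 1 to compound 4 (0.93 log units; beyond the scatter)).

Nothing measured here explains this loss. Going by these compounds, whether a methyl ester of carboxymethyl, an amine or a longer carboxylic acid chain would give a similar number remains open.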